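A Ring Replaces a Chain on the Amide Nitrogen

The compounds below may be only part of what the source reports. "The series", "measured", "known", "first", "only" and "open" are said of these compounds alone.

In an ADME assay on MRC5 cells (Homo sapiens) for inhibition, with a stated time of 72 h (on this read-out higher numbers stand for an effect only at larger amounts of compound and lower numbers for an effect already at smaller amounts), compound 3 `COc1cccc(OC)c1C(=O)Nc1c[nH]nc1C(=O)NCCCN(C)C` gives > 50000 nM as a limit of the assay and not as a number. Compound 1 `COc1cccc(OC)c1C(=O)Nc1c[nH]nc1C(=O)NC1CC1` gives > 50000 nM as a limit too. Compound 2 `COc1cccc(OC)c1C(=O)Nc1c[nH]nc1C(=O)NCCN1CCCC1` gives > 50000 nM as a limit as well. The record so far is the limit of > 50000 nM in this assay, at which 3 of the 3 values shown sit, and nothing finer. Compound 4 `COc1cccc(OC)c1C(=O)Nc1c[nH]nc1C(=O)NC1CCC(C)CC1` carries 4-methylcyclohexyl in place of 3-(dimethylamino)propyl on an amide-type nitrogen, counted in full as 4-methylcyclohexyl in place of 3-(dimethylamino)propyl on an amide-type nitrogen here. The measured steps on this same nitrogen give no size: there is a step that the two limits leave unreadable from compound 1 to compound 2 and a step that the two limits leave unreadable from compound 1 to compound 3 and also a step that the two limits leave unreadable from compound 2 to compound 3 among these compounds. The expected change is therefore a number no higher from compound 3 to compound 4 (the limit leaves the size open) with no direction favoured. For compound 4 the estimate is 50000 nM with an expected range from 20000 nM to 100000 nM and quite possibly another limit.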

Compound 4, half-maximal effective concentration: 45000 nM
Estimate against measurement, compound 4: 1.1-fold (0.05 log units) above; the measured number falls inside the stated range.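

Compound 4, with 4-methylcyclohexyl on the amide-type nitrogen, is the first compound in this assay to give a number and not a limit, while the others remain at a limit: the limit of > 50000 nM in this assay, at which 3 of the 4 values shown sit.

The readable steps are an at least 1.1-fold lower number from compound 3 to compound 4 (0.04 log units; that floor lies within the scatter), an at least 1.1-fold lower number from compound 2 to compound 4 (0.04 log units; that floor lies within the scatter) and an at least 1.1-fold lower number from compound 1 to compound 4 (0.04 log units; that floor lies within the scatter). As far as these compounds go, each is only a floor, so the change is known to alter the form of the reading, but its true size remains unknown.

From the compounds shown here alone, whether plain cyclohexyl, a phenyl ring or a longer carbon chain on this nitrogen would also give a number stays open.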